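Methyl on the phenyl of compound 3

A few compounds are considered here, and "the series" means these few. Any claim that something is new, unique, unknown or untested is made for them only; others in the source may bear on it.

Values so far in a functional assay on MCF7 cells (Homo sapiens) for antiproliferative activity, read by MTT assay, with a stated time of 48 h; a higher number here means a weaker inhibitor, a lower number a stronger inhibitor
- compound 1 `Cc1ccc(-c2cc(NC(=O)/C=C/c3ccc(C(F)(F)F)cc3)n[nH]2)cc1` gives 720 nM
- compound 2 `O=C(/C=C/c1ccc([N+](=O)[O-])cc1)Nc1cc(-c2ccccc2)[nH]n1` gives 630 nM
- compound 3 `O=C(/C=C/c1ccc(Br)cc1)Nc1cc(-c2ccccc2)[nH]n1` gives 1240 nM

Compound 3 stands within the scatter of both compound 1 and compound 2, so the three values set no order. Compound 4 `Cc1ccc(-c2cc(NC(=O)/C=C/c3ccc(Br)cc3)n[nH]2)cc1` follows from compound 3 by methyl in place of hydrogen on an aromatic carbon, which turns phenyl into 4-methylphenyl. Going by the values given here, no measured step isolates this change. Among the compounds with values here, the only measured step, a 2.0-fold higher number from compound 2 to compound 3 (0.29 log units; within the scatter), is bromo in place of nitro at a different place and stays within the scatter. Compound 3 and compound 1 differ in two places, yet compound 1, which carries 4-methylphenyl, gives 720 nM, within the scatter of the other two. No step beyond the scatter is therefore expected in this assay, and no direction is favoured. The expected step is a 1.2-fold lower number from compound 3 to compound 4 (0.09 log units; within the scatter). For compound 4 the estimate is 1000 nM, with an expected range from 450 nM to 2200 nM.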

Compound 4, half-maximal inhibitory concentration: 1370 nM
For compound 4 the middle estimate is 1.4-fold (0.14 log units) below the measured one; the measured number falls inside the stated range.
By their numbers in this assay, from the lowest: compounds 2, 1, 3 and 4 (each within the scatter of the next, the first and the last beyond it).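

In this assay the change from phenyl to 4-methylphenyl now has a step of its own, a 1.1-fold higher number from compound 3 to compound 4 (0.04 log units; within the scatter), so methyl in place of hydrogen at this position, para to a large group, gives no step beyond the scatter. With 4-methylphenyl held constant, the exchange of trifluoromethyl for bromo gives a 1.9-fold higher number from compound 1 to compound 4 (0.28 log units; within the scatter), which also stays within the scatter and adds a second substituent exchange that does not separate the compounds. No measured evidence bears on these results.

On these data alone, whether an amine or a carboxylic acid in place of the methyl would give a step beyond the scatter stays open. As far as these compounds go, the methyl step can be read only with bromo present, so whether it holds with nitro or trifluoromethyl also stays open.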